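A few compounds are considered here, and "the series" means these few. Any claim that something is new, unique, unknown or untested is made for them only; others in the source may bear on it.

Among the compounds with values here, in a functional assay on HeLa cells (Homo sapiens) for inhibition, read by CCK-8 assay, with a stated time of 72 h, tested at 8 uM (a lower number here means less inhibition of growth, a higher number more inhibition of growth at the concentration tested), compound 1 `Nc1ccccc1NC(=O)/C=C/c1ccc(CSc2ccc(Cl)cc2)cc1` gives 17.3%, the lowest of the three numbers so far. Compound 3 `Nc1ccccc1NC(=O)c1ccc(CSc2ccc(Br)cc2)cc1` reaches 38.2%, and compound 2 `Cc1ccc(SCc2ccc(C(=O)Nc3ccccc3N)cc2)cc1` reaches 79.2%. The move to compound 4 `Nc1ccccc1NC(=O)/C=C/c1ccc(CSCCc2ccccc2)cc1` is phenethyl in place of 4-chlorophenyl on a sulfur. Within the data shown here, only one measured step bears on the aromatic group on the sulfur: a number 41 percentage points lower from compound 2 to compound 3 (beyond the scatter), with bromo in place of methyl on an aromatic carbon. That step is large, but it is a different change, and compounds 2 and 3 also differ from compound 1 elsewhere, so it is only a loose guide. Compound 4, like compound 2, carries no halogen. A moderate rise is therefore expected, a number 17.7 percentage points higher from compound 1 to compound 4 (beyond the scatter). The estimate for compound 4 is 35%, with an expected range from 12% to 65%.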

Compound 4, percent growth inhibition at one concentration: 3.57%
For compound 4 the middle estimate is 31.4 percentage points above the measured one; the measured number lies below the stated range.
By their numbers in this assay, from the lowest: compound 4; then compound 1; then compound 3; then compound 2.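

Within the data shown here, on the core of compound 1, swapping 4-chlorophenyl for phenethyl on the sulfur gives a number 13.7 percentage points lower from compound 1 to compound 4 (beyond the scatter) in this assay and leaves compound 4 with the lowest number so far. This single swap removes the chlorine and adds the phenethyl chain together, so the data cannot separate the two. Nothing available explains the drop.

Still open, as far as these compounds go, is how this core responds to an unsubstituted phenyl or a benzyl group on the sulfur. A chain ending in an amine at this place is also untested in the compounds shown here.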